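Swapping the Terminal Alkyne Chain for a Triazole

The source may hold more compounds than are shown below. What is called first, only, known or untested is meant among the compounds shown, and "the series" means these compounds.

Compound 1 `C#CCCCCOC(=O)/C=C/c1ccc(OC(C)=O)c(OC(C)=O)c1`: 920 nM in an assay for inhibition of Polyunsaturated fatty acid 5-lipoxygenase (Homo sapiens), read by HPLC, with a stated time of 10 min; on this read-out higher numbers stand for weaker inhibition and lower numbers for stronger inhibition
Compound 2 `C#CCCCCCOC(=O)/C=C/c1ccc(OC(C)=O)c(OC(C)=O)c1`: 470 nM
Compound 3 `C#CCCCCCCCCOC(=O)/C=C/c1ccc(OC(C)=O)c(OC(C)=O)c1`: 180 nM

Compound 3 has the lowest number of the three; the steps of a 5.1-fold lower number from compound 1 to compound 3 (0.71 log units; beyond the scatter) and a 2.6-fold lower number from compound 2 to compound 3 (0.42 log units; beyond the scatter) lie beyond the scatter, while the step of a 2.0-fold lower number from compound 1 to compound 2 (0.29 log units; within the scatter) does not. Compound 4 `CC(=O)Oc1ccc(/C=C/C(=O)OCCCCc2cnnn2CCCO)cc1OC(C)=O` carries 1-(3-hydroxypropyl)-1H-1,2,3-triazol-5-yl in place of hex-5-yn-1-yl on a saturated chain carbon, four bonds along the chain from an oxygen next to a carbonyl group. The measured steps all lengthen a chain that ends in a triple bond; none brings in a ring, nitrogen or a hydroxyl group, so they bear on compound 4 only loosely. The step of a 5.1-fold lower number from compound 1 to compound 3 (0.71 log units; beyond the scatter) shows that a larger group at this position lowered the number, yet the new group is of a different kind, so a small rise is expected, a 2.2-fold higher number from compound 3 to compound 4 (0.35 log units; beyond the scatter). For compound 4 the expected value in this assay is 400 nM, with a range from 100 nM to 2000 nM.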

Compound 4, half-maximal inhibitory concentration: 6100 nM
The estimate for compound 4 lay 15-fold (1.18 log units) below the measured number; measured number above the stated range.
By their numbers in this assay, from the lowest: compound 3; then compounds 2 and 1 (each within the scatter of the next); then compound 4.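

In this assay, replacing the alkyne chain with 1-(3-hydroxypropyl)-1H-1,2,3-triazol-5-yl raises the number sharply (a 34-fold higher number from compound 3 to compound 4 (1.53 log units; beyond the scatter)). The number also rises against the two shorter alkyne chains (a 13-fold higher number from compound 2 to compound 4 (1.11 log units; beyond the scatter)) and (a 6.6-fold higher number from compound 1 to compound 4 (0.82 log units; beyond the scatter)), so a larger group at this position does not always lower it. Nothing measured here explains the rise.

Going by these compounds, the ring, its nitrogens and the hydroxyl group enter together, so their separate contributions remain unknown. A triazole carrying a plain propyl chain would test the hydroxyl group alone.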